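Replacing the 4-phenylphenyl group of compound 1

The source may hold more compounds than are shown below. What is called first, only, known or untested is meant among the compounds shown, and "the series" means these compounds.

Going by the values given here, in a functional assay on HOS cells (Homo sapiens) for inhibition, with a stated time of 72 h (on this read-out higher numbers stand for weaker inhibition and lower numbers for stronger inhibition), compound 1 `NC1CCC(Nc2nc(NCc3ccc(-c4ccccc4)cc3)c3ncn(C4CCCC4)c3n2)CC1` gives 290 nM and so holds the higher of the two numbers measured so far. Among the compounds with values here, compound 2 `NC1CCC(Nc2nc(NCc3ccc(-c4ccccc4O)nc3)c3ncn(C4CCCC4)c3n2)CC1` gives 14 nM and is its only neighbour on this scale, with a gap between them that lies beyond the scatter.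

Compound 3 `NC1CCC(Nc2nc(NCc3cc(Cl)ccc3O)c3ncn(C4CCCC4)c3n2)CC1` awaits measurement. It keeps the core of compound 1 but carries 5-chloro-2-hydroxyphenyl in place of 4-phenylphenyl on a saturated chain carbon bound to a nitrogen on an aromatic ring. Within the data shown here, no measured pair isolates this change, so the data offer only a loose guide to its effect. A modest move towards a lower number is expected in this assay, and it may not clear the scatter. The estimated step is a 1.9-fold lower number from compound 1 to compound 3 (0.29 log units; within the scatter) and remains an expectation only. In this assay compound 3 is expected at 150 nM within an estimated range of 40 nM to 600 nM until the measurement is made.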

Compound 3, half-maximal inhibitory concentration: 490 nM
Compound 3: middle estimate off by 3.3-fold (0.51 log units), on the low side; the range from low to high includes it.
By their numbers in this assay, from the lowest: compound 2; then compounds 1 and 3 (each within the scatter of the next).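

In this assay, the step of a 1.7-fold higher number from compound 1 to compound 3 (0.23 log units; within the scatter) stays within the scatter, so 5-chloro-2-hydroxyphenyl and 4-phenylphenyl cannot be told apart at this position on a saturated chain carbon bound to a nitrogen on an aromatic ring. Going by these compounds alone, this is the first single-place comparison, and it shows that the read-out holds within the scatter when the 12 heavy atoms and two aromatic rings of 4-phenylphenyl give way to the 8 heavy atoms and single aromatic ring of 5-chloro-2-hydroxyphenyl, which also brings 1 hydrogen-bond donor and 1 hydrogen-bond acceptor. No available evidence bears on why these two groups read alike.

The chlorine and the hydroxyl enter together in compound 3, so the compounds shown leave open what either contributes alone, and whether the two changes offset each other or neither has any effect on the read-out. Also open, on these data alone, is how this position would respond to a plain phenyl, or to an amine or a carboxylic acid on the phenyl ring in place of the hydroxyl.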